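A few compounds are considered here, and "the series" means these few. Any claim that something is new, unique, unknown or untested is made for them only; others in the source may bear on it.

Compound 1 `C#CCSc1nc(Sc2nccs2)c(C#N)c(-c2ccc(Br)cc2)n1`: 8530 nM
Compound 2 `C#CCSc1nc(Sc2nccs2)c(C#N)c(-c2ccc(Cl)cc2)n1`: 3620 nM
Compound 3 `C#CCSc1nc(Sc2nccs2)c(C#N)c(-c2ccc(C)cc2)n1`: 1620 nM

All three values come from a functional assay on PC-3 cells (Homo sapiens) for antiproliferative activity, read by MTT assay, with a stated time of 72 h; a lower number here means a stronger inhibitor, a higher number a weaker inhibitor. Compound 3 has the lowest number of the set at 1620 nM, and its gaps to the other two lie beyond the usual scatter. The next change gives compound 4 `C#CCSc1nc(Sc2nccs2)c(C#N)c(-c2ccc[nH]2)n1`, with 1H-pyrrol-2-yl in place of 4-methylphenyl on an aromatic carbon.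

The measured steps offer only indirect guidance, since each one swaps a single small group and none replaces the whole ring. They are a 2.4-fold lower number from compound 1 to compound 2 (0.37 log units; beyond the scatter), a 2.2-fold lower number from compound 2 to compound 3 (0.35 log units; beyond the scatter) and a 5.3-fold lower number from compound 1 to compound 3 (0.72 log units; beyond the scatter), all modest. A modest step in this assay therefore seems a reasonable expectation, although a larger one cannot be ruled out. The direction is uncertain, but a higher number is more likely, as compound 3 already has the lowest value at 1620 nM. The expected change is a 2.2-fold higher number from compound 3 to compound 4 (0.33 log units; beyond the scatter). For compound 4 the estimated value is 3500 nM, with an expected range from 900 nM to 14000 nM.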

Compound 4, half-maximal inhibitory concentration: > 20000 nM
Compound 4: only a limit was reported (the forecaster's own chance of this, stated with the estimate: 5%); middle value at least 5.7-fold (0.75 log units) from the limit.
By their numbers in this assay, from the lowest: compound 3; then compound 2; then compound 1. At a limit, above all of these: compound 4.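

Compound 4 in this assay stands at a limit, not a number: the limit of > 20000 nM in this assay, at which 1 of the 4 values shown sits.

Placing 1H-pyrrol-2-yl where 4-methylphenyl stood gives an at least 12-fold higher number from compound 3 to compound 4 (1.09 log units; beyond the scatter), a large step, whereas the earlier swaps of one small group on the six-membered ring were all modest. The same exchange gives an at least 5.5-fold higher number from compound 2 to compound 4 (0.74 log units; beyond the scatter) and an at least 2.3-fold higher number from compound 1 to compound 4 (0.37 log units; beyond the scatter), so replacing the whole ring at this position leaves compound 4 weaker, beyond the scatter, than all three earlier compounds.

The exchange alters ring size, the ring nitrogen with its hydrogen and the 4-substituent all at once, and compound 4 alone cannot separate these changes. Going by these compounds, how a plain phenyl, a thiophen-2-yl or a 1-methyl-1H-pyrrol-2-yl group would read at this position remains open.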